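A few compounds are considered here, and "the series" means these few. Any claim that something is new, unique, unknown or untested is made for them only; others in the source may bear on it.

Measured compounds:
- compound 1 `COc1ccccc1-c1csc2cnc(Nc3ccc(NC(=O)[C@@H]4CCCNC4)cc3)nc12` — 360 nM
- compound 2 `COc1ccccc1-c1csc2cnc(Nc3ccc(C(=O)NC4CCNCC4)cc3C(F)(F)F)nc12` — 2090 nM

Of the two measured compounds, compound 1 stands lower in a functional assay on U-87MG ATCC cells for inhibition, with U-87 MG (Homo sapiens) as the target, read by MTT assay, with a stated time of 72 h (on this read-out higher numbers stand for weaker inhibition and lower numbers for stronger inhibition), and compound 2 gives the higher number, 2090 nM. Among the compounds with values here, no single-site step links the two, and the two values are all that can be said of that pair: compound 1 gives 360 nM, a clearly separated and lower number than compound 2.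

The step that matters here runs from compound 1 to compound 3 `COc1ccccc1-c1csc2cnc(Nc3ccc(NC(=O)[C@H]4CCCNC4)cc3)nc12`. The change is the two compounds have the same atoms and bonds and differ only in configuration as drawn: 1 of 1 stereo elements differ; a stereocentre at a saturated ring carbon is drawn R in compound 1 and S in compound 3. Nothing leaves and nothing enters; the stereocentre at the saturated ring carbon is simply drawn the other way. Within the data shown here, no measured pair in this set shows what such a stereochemical inversion does in this assay, so the size and direction of the step are open. A swap of a single stereocentre can leave activity where it is or move it by a considerable margin, so the expectation has to be wide. It is expected that compound 3 will lie somewhat weaker than compound 1, with the step from compound 1 to compound 3 estimated as a 1.5-fold higher number from compound 1 to compound 3 (0.18 log units; within the scatter), though a step of no size beyond the scatter is also plausible. Compound 3 is estimated at 550 nM, within a range of 180 nM to 2500 nM.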

Compound 3, half-maximal inhibitory concentration: 300 nM
Estimate against measurement, compound 3: 1.8-fold (0.26 log units) above, within the range that was stated.
By their numbers in this assay, from the lowest: compounds 3 and 1 (each within the scatter of the next); then compound 2.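

In this assay, inverting the stereocentre at the saturated ring carbon gives a 1.2-fold lower number from compound 1 to compound 3 (0.08 log units; within the scatter), so the two configurations cannot be told apart on this read-out. Within the data shown here, this is the first single-site step in the set, and it shows that, on this scaffold and in these cells, the drawn configuration at this carbon does not produce a difference that stands out from the usual scatter of repeated measurements. The pair gives a direct reading of this one stereocentre, with nothing else to account for, because of a single fact: the fact that compounds 1 and 3 differ only in the configuration as drawn.

The compounds shown leave open whether this indifference to configuration holds only for the unsubstituted saturated ring, or would persist with a methyl or acetyl group on the ring nitrogen, or with a carboxylic acid in place of the ring amine. They also leave open what the cell read-out reflects at the level of a molecular target, so the step says nothing on whether the two configurations act alike at any single protein.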